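Carbamate in place of the pyridylmethyl amide at the pyrazole core

The source may report more compounds than this note shows. Statements on the series, on what has been measured and on what is new or still open speak of the compounds shown alone.

Measured so far:
compound 1 `Cc1cc(C(=O)NCc2ccncc2)nn1Cc1cc(Cl)ccc1OCc1ccccc1` gives 79.4 nM in an assay on CHO-K1 cells for displacement of a labelled ligand from prostaglandin E2 receptor EP1 subtype (Homo sapiens); on this read-out higher numbers stand for weaker inhibition and lower numbers for stronger inhibition
compound 2 `Cc1cc(C(=O)NN2CCOCC2)nn1Cc1cc(Cl)ccc1OCC(C)C` gives 251 nM in this assay
compound 3 `Cc1cc(NC(=O)C2CCCCC2)nn1Cc1cc(Cl)ccc1OCC(C)C` gives 31.6 nM in this assay

Compound 1 stands second highest of the three numbers. Its nearest neighbour is compound 3, with a lower number, and its furthest is compound 2, with a higher number; both gaps lie beyond the scatter.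

The unmeasured compound 4 `Cc1cc(NC(=O)OCC(C)C)nn1Cc1cc(Cl)ccc1OCc1ccccc1` differs from compound 1 in one place: (isobutoxycarbonyl)amino in place of ((pyridin-4-yl)methyl)carbamoyl on an aromatic carbon. The shared core and the benzyloxy-bearing side chain are unchanged.

Within the data shown here, the only measured step that bears on this change is a 7.9-fold lower number from compound 2 to compound 3 (0.90 log units; beyond the scatter). That step also turned the carbamoyl attachment at the same ring carbon round into an amino group carrying a carbonyl, and it gave a clearly lower number. The change from compound 1 to compound 4 is of the same kind, though the entering group is a carbamate rather than a cyclohexylcarbonyl, so a smaller gain is the more cautious reading. A lower number beyond the scatter is therefore expected, a 2.5-fold lower number from compound 1 to compound 4 (0.39 log units; beyond the scatter).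

Compound 4 is estimated at 32 nM in this assay, with a range of 10 nM to 100 nM.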

Compound 4, half-maximal inhibitory concentration: 25.1 nM
Beside the measured number, compound 4's estimate is 1.3-fold (0.11 log units) above it, and the stated range covers the measured number.
By their numbers in this assay, from the lowest: compounds 4 and 3 (each within the scatter of the next); then compound 1; then compound 2.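

In this assay, a 3.2-fold lower number from compound 1 to compound 4 (0.50 log units; beyond the scatter), so an amino-linked carbonyl group on this aromatic carbon is again linked to a lower number than a carbamoyl-linked group, now with the benzyloxy-bearing side chain as well as the isobutoxy-bearing one of a 7.9-fold lower number from compound 2 to compound 3 (0.90 log units; beyond the scatter). The entering (isobutoxycarbonyl)amino carries no ring, which shows that neither the six-membered aromatic ring of the ((pyridin-4-yl)methyl)carbamoyl group nor a ring such as the cyclohexyl of compound 3 is required for a number in this lower range. Among these compounds, no supporting measurement is available to explain the step, and these data show only that the number moves with the exchange of the whole group.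

The step changes the direction of the linkage and the group beyond it together, so the share of each remains unresolved, and (cyclohexylcarbonyl)amino on the benzyloxy-bearing side chain would help separate the contribution of the carbamate oxygen from that of the side chain. Also open, as far as these compounds go, is how far the trend extends to a free amine or a carboxylic acid at this aromatic carbon, or to a longer chain in place of the isobutyl of the carbamate.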